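Hydroxamate tail swaps on an imidazoline urea core

A few compounds are considered here, and "the series" means these few. Any claim that something is new, unique, unknown or untested is made for them only; others in the source may bear on it.

Compound 1 `CCOc1cc(C(C)(C)C)ccc1C1=NC(c2ccc(Cl)cc2)C(c2ccc(Cl)cc2)N1C(=O)NCCCCCCCC(=O)NO`, compound 2 `CCOc1cc(C(C)(C)C)ccc1C1=NC(c2ccc(Cl)cc2)C(c2ccc(Cl)cc2)N1C(=O)N1CCN(Cc2ccc(C(=O)NO)cc2)CC1` and compound 3 `CCOc1cc(C(C)(C)C)ccc1C1=NC(c2ccc(Cl)cc2)C(c2ccc(Cl)cc2)N1C(=O)N1CCN(CCCCCCCC(=O)NO)CC1` share a core and differ in the hydroxamate-bearing arm. In a functional assay on A549 cells (Homo sapiens) for antiproliferative activity, read by CCK-8 assay, with a stated time of 72 h (on this read-out higher numbers stand for weaker inhibition and lower numbers for stronger inhibition), compound 1 gives 4850 nM, compound 2 gives 2170 nM and compound 3 gives 2010 nM. The step of a 1.1-fold higher number from compound 3 to compound 2 (0.03 log units; within the scatter) shows that 4-(hydroxycarbamoyl)phenyl in place of 6-(hydroxycarbamoyl)hexyl on a saturated chain carbon bound to an amine nitrogen in a ring left the read-out essentially unchanged. Compound 4 `CCOc1cc(C(C)(C)C)ccc1C1=NC(c2ccc(Cl)cc2)C(c2ccc(Cl)cc2)N1C(=O)NCc1ccc(C(=O)NO)cc1` carries the same kind of change relative to compound 1, namely (4-(hydroxycarbamoyl)phenyl in place of 6-(hydroxycarbamoyl)hexyl on a saturated chain carbon bound to an amide-type nitrogen), though here the place is a saturated chain carbon bound to an amide-type nitrogen rather than to an amine nitrogen in a ring. The difference between the cores of compound 1 and compound 3 is not broken down here. Because the earlier step of a 1.1-fold higher number from compound 3 to compound 2 (0.03 log units; within the scatter) was within the scatter, the step of a 1.0-fold higher number from compound 1 to compound 4 (0.01 log units; within the scatter) is expected to be similarly small. Compound 4 is therefore estimated at 5000 nM, between 2500 nM and 10000 nM.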

Compound 4, half-maximal inhibitory concentration: 7640 nM
Compound 4: the middle estimate sits 1.5-fold (0.18 log units) below what was measured; the measured number falls inside the stated range.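

In this assay, placing 4-(hydroxycarbamoyl)phenyl in place of 6-(hydroxycarbamoyl)hexyl on a saturated chain carbon bound to an amide-type nitrogen gave a 1.6-fold higher number from compound 1 to compound 4 (0.20 log units; within the scatter). Set beside the earlier step, the same swap behaved alike on both cores: the same change on two cores in this assay, a 1.1-fold higher number (0.03 log units; within the scatter) from compound 3 to compound 2 and a 1.6-fold higher number (0.20 log units; within the scatter) from compound 1 to compound 4, 1.5-fold (0.16 log units) apart, within the scatter of two such steps. For the compounds shown here, this shows that the swap carried across these two cores without a detectable change in the read-out, but it rests on only two pairs and does not show that the same would hold on any other core.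

The compounds shown leave open how a shorter or longer hydroxamate chain would compare. They also leave open whether a carboxylic acid in place of the hydroxamate would give a similar read-out.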